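Working notes on a bromo-for-pyridin-2-yl exchange

The source may hold more compounds than are shown below. What is called first, only, known or untested is meant among the compounds shown, and "the series" means these compounds.

Measured so far:
compound 1, `CC(C)(C)Cc1csc(N)c1C(=O)c1cccc(Cl)c1`: 8%
compound 2, `CC(C)(C)Cc1c(-c2ccccn2)sc(N)c1C(=O)c1ccc(Cl)cc1`: 1%

Both measured compounds come from an assay on CHO cells for displacement of a labelled ligand from adenosine receptor A3 (Homo sapiens), read by scintillation counting, tested at 10 uM; on this read-out lower numbers stand for less inhibition and higher numbers for more inhibition at the one concentration tested (going by the name of the read-out). Compound 1 gives 8% in this assay, and compound 2 gives 1%. Among the measured compounds shown here, the two numbers lie within the scatter of each other, so nothing separates compound 1 from compound 2 on this read-out; both sit at the low end of what the measurement can report, and no step between measured compounds is available in this set.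

Compound 3, `CC(C)(C)Cc1c(Br)sc(N)c1C(=O)c1ccc(Cl)cc1`, has not been measured. It differs from compound 2 in one place: bromo in place of pyridin-2-yl on an aromatic carbon, that is, a one-atom group in place of a six-membered aromatic ring on the five-membered aromatic ring with one sulfur. For the measured compounds named here, there is no measured pair that isolates this change, so the expectation rests only on where compound 2 stands, which is at a low number that compound 1 does not move away from.

Compound 3 is expected to stay close to compound 2, with a step of a number 5 percentage points higher from compound 2 to compound 3 (within the scatter) that lies within the scatter rather than beyond it. The estimate for compound 3 in this assay is therefore 6%, with a range from -6% to 22%.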

Compound 3, a percentage reported as inhibition, at one concentration (the size of the read-out at that concentration, not a potency): 1%
Compound 3: middle estimate off by 5 percentage points, on the high side, and the stated range covers the measured number.
By their numbers in this assay, from the lowest: compounds 2, 3 and 1 (each within the scatter of the next).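

Among the compounds shown here, this is the first pair that isolates a change at the ring carbon next to the ring sulfur: in this assay, bromo in place of pyridin-2-yl gives no change at the digits printed from compound 2 to compound 3 (within the scatter). Going from a six-membered aromatic ring to a single bromine atom at this place therefore leaves the read-out where it was, and with compound 3 at 1%, both members of the pair sit at the low end of what the measurement can report, so the pair cannot show whether this place matters when inhibition is higher. Nothing measured here bears on why the two compounds read alike.

Still open, going by these compounds, is whether any group at this place would lift the number clear of the scatter, for example a primary amine, a carboxylic acid, a morpholine ring or a longer alkyl chain. Also open, on these data alone, is whether the neopentyl group or the amino group, changed on their own with either bromo or pyridin-2-yl in place, would move the read-out at all.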